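Adding a Second Methyl to the Sulfonyl Aryl Ring

The source may report more compounds than this note shows. Statements on the series, on what has been measured and on what is new or still open speak of the compounds shown alone.

Measured compounds:
Compound 1 `O=C(/C=C/c1cccc(NS(=O)(=O)c2cccc(Cl)c2)c1)c1nc2ccccc2[nH]1`: 2510 nM
Compound 2 `Cc1ccccc1S(=O)(=O)Nc1cccc(/C=C/C(=O)c2nc3ccccc3[nH]2)c1`: 4060 nM
Compound 3 `Cc1ccc(S(=O)(=O)Nc2cccc(/C=C/C(=O)c3nc4ccccc4[nH]3)c2)cc1`: 3220 nM

All three share the same core and differ only in the aryl group on the sulfonyl sulfur. In a functional assay on 143B cells (Homo sapiens) for antiproliferative activity, read by MTT assay, with a stated time of 48 h (a higher number here means a weaker inhibitor, a lower number a stronger inhibitor), the numbers lie close together: a 1.6-fold higher number from compound 1 to compound 2 (0.21 log units; within the scatter), a 1.3-fold higher number from compound 1 to compound 3 (0.11 log units; within the scatter), and a 1.3-fold lower number from compound 2 to compound 3 (0.10 log units; within the scatter). Compound 3 therefore stands alongside compound 1 and compound 2, separated from neither beyond the scatter.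

Compound 4 `Cc1cc(C)cc(S(=O)(=O)Nc2cccc(/C=C/C(=O)c3nc4ccccc4[nH]3)c2)c1` differs from compound 3 by 3,5-dimethylphenyl in place of 4-methylphenyl on a sulfonyl sulfur. The steps bearing on this change, a 1.3-fold higher number from compound 1 to compound 3 (0.11 log units; within the scatter) and a 1.3-fold lower number from compound 2 to compound 3 (0.10 log units; within the scatter), both at the same position, were within the scatter, so the expected step of a 1.1-fold higher number from compound 3 to compound 4 (0.04 log units; within the scatter) is also within the scatter. Compound 4 is estimated to give 3500 nM, with a range from 1700 nM to 7000 nM.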

Compound 4, half-maximal inhibitory concentration: 3330 nM
Beside the measured number, compound 4's estimate is 1.1-fold (0.02 log units) above it, and the stated range covers the measured number.
By their numbers in this assay, from the lowest: compounds 1, 3, 4 and 2 (each within the scatter of the next).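

In this assay, 3,5-dimethylphenyl on the sulfonyl sulfur stays within the scatter of all three earlier groups (a 1.0-fold higher number from compound 3 to compound 4 (0.01 log units; within the scatter); a 1.2-fold lower number from compound 2 to compound 4 (0.09 log units; within the scatter); a 1.3-fold higher number from compound 1 to compound 4 (0.12 log units; within the scatter)). A ring with two methyl groups therefore joins the one-methyl and chloro rings in a single tight cluster, and this assay does not separate any of the four compounds. No measurement shown here accounts for this result. From the compounds shown here alone, whether an amine or a carboxylic acid on this ring, or a longer chain in its place, would move the number beyond the scatter remains open.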